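This account rests on a few compounds, and the source may have more. Where it says the series, first, only, none or still open, it means among the compounds named here.

In a functional assay on MCF7 cells (Homo sapiens) for cytotoxicity, read by MTT assay, with stated times of 6 h and 48 h (a lower number here means a stronger inhibitor, a higher number a weaker inhibitor), compound 1 `Cn1c(/C=C/C(=O)c2ccccc2)cc(Br)c1Br` gives 35400 nM and compound 2 `Cn1c(/C=C/C(=O)c2ccc[nH]2)cc(Br)c1Br` gives 450 nM, the lower of the two numbers. The gap is a 79-fold lower number from compound 1 to compound 2 (1.90 log units; beyond the scatter), with 1H-pyrrol-2-yl in place of phenyl on a carbonyl carbon. Compound 3 `O=C(/C=C/c1cc(Br)c(Br)[nH]1)c1ccc[nH]1` departs from compound 2 elsewhere: hydrogen in place of methyl on an aromatic nitrogen. For the measured compounds named here, the single measured step does not involve that nitrogen and so gives no size for this change, and no step beyond the scatter is expected in this assay. The expected change is a 1.1-fold higher number from compound 2 to compound 3 (0.05 log units; within the scatter). Compound 3 is expected at 500 nM, with an estimated range of 110 nM to 2200 nM.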

Compound 3, half-maximal inhibitory concentration: 72 nM
Compound 3: middle estimate off by 6.9-fold (0.84 log units), on the high side; the whole stated range lies above it.
By their numbers in this assay, from the lowest: compound 3; then compound 2; then compound 1.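

In this assay, the aromatic nitrogen that carried the methyl proves to be a position where the number responds: hydrogen in place of methyl gives a 6.3-fold lower number from compound 2 to compound 3 (0.80 log units; beyond the scatter). For the compounds shown here, the earlier step spoke only to the group on the carbonyl carbon, so this is the first sign that the other end of the molecule also counts. Nothing available accounts for this shift. Still open, from the compounds shown here alone, is how an ethyl group or a longer chain on this nitrogen would compare, and whether hydrogen in place of methyl would act alike with the phenyl of compound 1 on the carbonyl carbon.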